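Aryl Replacement at the Sulfur-Adjacent Carbon and A3 Inhibition

This account rests on a few compounds, and the source may have more. Where it says the series, first, only, none or still open, it means among the compounds named here.

Compound 1 `CC(C)(C)Cc1c(-c2c(F)cccc2F)sc(N)c1C(=O)c1ccc(Cl)cc1`: 1%
Compound 2 `CC(C)(C)Cc1c(/C=C/c2ccc(Cl)cc2)sc(N)c1C(=O)c1ccc(Cl)cc1`: 11%
Compound 3 `CC(C)(C)Cc1c(-c2ccccc2)sc(N)c1C(=O)c1ccccc1Cl`: 1%

In an assay on CHO cells for displacement of a labelled ligand from adenosine receptor A3 (Homo sapiens), read by scintillation counting, tested at 10 uM (a lower number here means less inhibition, a higher number more inhibition at the concentration tested (going by the name of the read-out)), compound 2 gives 11%, the highest of the three numbers, yet both compound 1 and compound 3 sit within the scatter of it, so the three compounds are not separated by this read-out. Going by the values given here, the only single-point step among them, a number 10 percentage points higher from compound 1 to compound 2 (within the scatter), is itself within the scatter.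

Compound 4 `COc1ccc(-c2sc(N)c(C(=O)c3ccc(Cl)cc3)c2CC(C)(C)C)cc1` has not been measured. Relative to compound 2 the change is 4-methoxyphenyl in place of 2-(4-chlorophenyl)ethenyl on an aromatic carbon. The step from compound 1 to compound 2 bears directly on it, since it concerns the same position and also exchanged an aryl group for the 2-(4-chlorophenyl)ethenyl group, and that step was within the scatter. Compound 3, carrying a phenyl at the same place with a different carbonyl substituent, gives 1%, again a low number. Among the compounds with values here, nothing among the measured compounds suggests that an aryl group at this carbon moves the inhibition beyond the scatter, so no step beyond the scatter is expected in this assay.

Compound 4 is therefore estimated at 4%, within 0% to 15%, which means an expected step of a number 7 percentage points lower from compound 2 to compound 4 (within the scatter).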

Compound 4, a percentage reported as inhibition, at one concentration (the size of the read-out at that concentration, not a potency): 2%
Compound 4: middle estimate off by 2 percentage points, on the high side, and the stated range covers the measured number.
By their numbers in this assay, from the lowest: compounds 1, 3, 4 and 2 (each within the scatter of the next).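

In this assay, the carbon next to the ring sulfur now carries a third kind of group on the shared core, and a number 9 percentage points lower from compound 2 to compound 4 (within the scatter) when 4-methoxyphenyl enters in place of 2-(4-chlorophenyl)ethenyl. The exchange for 2,6-difluorophenyl gives a number 1 percentage points higher from compound 1 to compound 4 (within the scatter) and so does not separate the two compounds either; at this place, then, neither a directly attached ring bearing a methoxy group nor the removal of the double bond outside aromatic rings shows a step beyond the scatter in this read-out. Nothing shown offers a measured explanation for these numbers.

Going by these compounds, all of these groups are carbon-ring substituents, so it remains open whether a carboxylic acid, a primary amine or a longer saturated alkyl chain at this carbon would give a step beyond the scatter in this assay on the same core. Because the read-out comes from one concentration, the compounds shown also leave open how these groups would compare in potency, and whether the amino group or the neopentyl group elsewhere on the core could change the picture.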